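Swapping the sulfonyl aryl group on a second core

The compounds below may be only part of what the source reports. "The series", "measured", "known", "first", "only" and "open" are said of these compounds alone.

Three close relatives of one chemical family have been tested for how well they displace a labelled ligand from a glutamate receptor. Compound 1 `COc1ccc(S(=O)(=O)c2cnc3cc(Cl)ccc3c2N2CCC(C)CC2)cc1Cl`, compound 2 `CC1CCN(c2c(S(=O)(=O)c3cccc(C#N)c3)cnc3cc(Cl)ccc23)CC1` and compound 3 `CC1CCN(c2c(S(=O)(=O)c3cccc(C#N)c3)cnc3ccc(F)cc23)CC1` share most of their skeleton and differ in the group attached to the sulfonyl sulfur and in the core that carries it. In an assay on isolated protein for displacement of a labelled ligand from metabotropic glutamate receptor 5 (Homo sapiens), with a stated time of 60 min, tested at 1 uM (on this read-out higher numbers stand for more inhibition at the one concentration tested (going by the name of the read-out) and lower numbers for less inhibition), compound 1 gives 93%, compound 2 gives 94% and compound 3 gives 93%. These three numbers sit close together, and none of them can be told apart from the others within the scatter of the measurement.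

Compounds 2 and 1 differ in one place only (3-chloro-4-methoxyphenyl in place of 3-cyanophenyl on a sulfonyl sulfur), and this change gave a number 1 percentage points lower from compound 2 to compound 1 (within the scatter). Compounds 3 and 2 carry the same group on the sulfonyl sulfur but sit on different cores; the difference between the two cores is not broken down here.

Compound 4 `COc1ccc(S(=O)(=O)c2cnc3ccc(F)cc3c2N2CCC(C)CC2)cc1Cl` has not yet been measured. It stands to compound 3 as compound 1 stands to compound 2: the same change, (3-chloro-4-methoxyphenyl in place of 3-cyanophenyl on a sulfonyl sulfur), on the same kind of position. Resting on the step from compound 2 to compound 1 in this assay, which was a number 1 percentage points lower from compound 2 to compound 1 (within the scatter), the expected step is a number 1 percentage points lower from compound 3 to compound 4 (within the scatter). Compound 4 is therefore estimated at 92% in this assay, with a likely range from 85% to 97%.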

Compound 4, a percentage reported as inhibition, at one concentration (the size of the read-out at that concentration, not a potency): 82%
Estimate against measurement, compound 4: 10 percentage points above, outside the stated range (below it).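

In this assay, putting 3-chloro-4-methoxyphenyl in place of 3-cyanophenyl on the sulfonyl sulfur gave a number 11 percentage points lower from compound 3 to compound 4 (beyond the scatter) on one core, and the same change on the other core gave a number 1 percentage points lower from compound 2 to compound 1 (within the scatter) on paper. For the compounds shown here, this does not show that the core decides how much the change matters, even though only one of the two steps stands clear of the scatter on its own, and two pairs are a very small basis for any rule about the series. Nor does it show that the change carries over exactly from one core to the other; what can be said is that the two steps cannot be told apart once the scatter of both is counted: the same change on two cores in this assay, a number 1 percentage points lower (within the scatter) from compound 2 to compound 1 and a number 11 percentage points lower (beyond the scatter) from compound 3 to compound 4, 10 percentage points apart, within the scatter of two such steps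

The compounds shown leave open which part of the 3-chloro-4-methoxyphenyl group goes with the step on the second core, since the chlorine and the methoxy group arrive together, and how a phenyl ring carrying only one of them would read. They also leave open how other groups on the sulfonyl sulfur, such as a phenyl ring carrying an amine or a carboxylic acid, would behave on these two cores.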